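The compounds below may be only part of what the source reports. "The series", "measured", "known", "first", "only" and "open" are said of these compounds alone.

Compound 1 `COc1cc(OC)c(OC)cc1/C=C/COC(=O)/C=C/c1ccc(OC)c(OC)c1` stands at 100% in a functional assay on the whole organism (strain Kunming) with Mus musculus as the target, with a stated time of 0.5 h, at a dose of 100 mg/kg by the intraperitoneal route; a lower number here means a stronger effect, a higher number a weaker effect of the compound at the dose given. Compound 2 `COc1cc(OC)c(OC)cc1/C=C/COC(=O)/C=C/c1ccccc1C(F)(F)F` gives 100% in this assay, and compound 3 `COc1cc(OC)c(OC)cc1/C=C/COC(=O)/C=C/c1cccc(Br)c1` gives 100%. The three measured steps all exchange the aryl group on the double-bonded chain carbon: no change at the digits printed from compound 1 to compound 2 (within the scatter), no change at the digits printed from compound 1 to compound 3 (within the scatter) and no change at the digits printed from compound 2 to compound 3 (within the scatter). Compound 1 is therefore level with compounds 2 and 3 at the digits shown, and the read-out does not separate any of the three.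

Compound 4 `COc1cc(OC)c(OC)cc1/C=C/COC(=O)/C=C/c1ccc(OC)c(OC)c1OC` differs from compound 1 in one place: methoxy in place of hydrogen on an aromatic carbon. Within the data shown here, none of the measured steps adds a group to the 3,4-dimethoxyphenyl ring; they replace the ring as a whole, so they bear on this change only indirectly. What they show is that three quite different aryl groups leave the read-out unmoved. On that basis no step beyond the scatter is expected for compound 4, the change from compound 1 to compound 4 being estimated as no change at the digits printed from compound 1 to compound 4 (within the scatter). Compound 4 is thus expected at 100%, with a range of 85% to 100%.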

Compound 4, a percentage reported as activity, at one dose (the size of the read-out at that dose, not a potency): 100%
Compound 4: middle estimate and measured number agree at the digits printed; measured number inside the range.
By their numbers in this assay, from the lowest: compounds 1, 2, 3 and 4 (each within the scatter of the next).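

Methoxy in place of hydrogen on this aromatic carbon, ortho to a large group and ortho to a methoxy group, gives no change at the digits printed from compound 1 to compound 4 (within the scatter) in this assay. The earlier steps shown here exchanged the whole aryl group, whereas this one keeps the 3,4-dimethoxyphenyl ring and adds a single group to it, so the lack of movement now extends to a change at one place on the ring. Nothing available gives a reason for this outcome.

The compounds shown leave open whether any group at this position can separate a compound from compound 1 in this assay, for example an amine, a carboxylic acid or a longer alkoxy chain in place of methoxy. As far as these compounds go, all four also share the same core and ester link, so the effect of changes there remains open.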